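Indole substituent swap: bromo to methyl in the series

This account rests on a few compounds, and the source may have more. Where it says the series, first, only, none or still open, it means among the compounds named here.

Compound 1 `CC/C(=C(/c1ccc(/C=C/C(=O)O)cc1)c1[nH]c2ccccc2c1Br)c1ccc(F)cc1Cl` gives 8.53 nM in a functional assay on MCF7 cells (Homo sapiens) for antiproliferative activity, read by luminescence and CellTiter-Glo, with a stated time of 5 days; on this read-out higher numbers stand for weaker inhibition and lower numbers for stronger inhibition. Its number lies between those of compound 3 `CC/C(=C(/c1ccc(/C=C/C(=O)O)cc1)c1[nH]c2ccccc2c1Cl)c1ccsc1C#N`, which gives 7.56 nM in this assay, and compound 2 `CC/C(=C(/c1ccc(/C=C/C(=O)O)cc1)c1[nH]c2ccccc2c1Cl)c1ccccc1C(F)(F)F`, which gives 13 nM; both gaps are within the usual scatter, so the three compounds cannot be ranked on these data. Among the compounds with values here, the only single-point step measured so far, a 1.7-fold lower number from compound 2 to compound 3 (0.24 log units; within the scatter), concerns the aryl group on the chain and leaves the indole untouched.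

Compound 4 `CC/C(=C(/c1ccc(/C=C/C(=O)O)cc1)c1[nH]c2ccccc2c1C)c1ccc(F)cc1Cl` differs from compound 1 by methyl in place of bromo on an aromatic carbon, read one bond further out as 3-bromo-1H-indol-2-yl to 3-methyl-1H-indol-2-yl. Within the data shown here, no measured step changes this group; what the set does show is that chloro at the same place, in compounds 2 and 3, sits within scatter of the bromo in compound 1. A step from compound 1 to compound 4 no larger than the scatter is therefore expected, with no direction to be read from the data, a 1.4-fold higher number from compound 1 to compound 4 (0.15 log units; within the scatter). Compound 4 is estimated at 12 nM in this assay, within a range of 4 nM to 35 nM.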

Compound 4, half-maximal inhibitory concentration: 4.78 nM
Beside the measured number, compound 4's estimate is 2.5-fold (0.40 log units) above it; low and high end bracket the measured number.
By their numbers in this assay, from the lowest: compounds 4, 3, 1 and 2 (each within the scatter of the next, the first and the last beyond it).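

Methyl in place of bromo on this aromatic carbon gives a 1.8-fold lower number from compound 1 to compound 4 (0.25 log units; within the scatter) in this assay. The earlier compounds shown here carried only halogens here, bromo or chloro, whereas compound 4 shows that a carbon group can stand at this place on the shared core and keep the number in the same low nanomolar range as compound 1. With the 3-methyl-1H-indol-2-yl group, a halogen at this place is therefore not required for this level of antiproliferative activity, and no measurement on hand accounts for the size of the step.

As far as these compounds go, it remains open whether an amine, a methoxy group or a longer chain such as ethyl would hold this range at the same place. From the compounds shown here alone, it is also open whether methyl would behave the same way alongside the 2-cyanothiophen-3-yl group of compound 3.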